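This account rests on a few compounds, and the source may have more. Where it says the series, first, only, none or still open, it means among the compounds named here.

Measured compounds:

- compound 1 `COC(=O)[C@@]1(C)CCC=C2[C@@H]1CC[C@@H](C)[C@]2(C)Cc1c[nH]c2ccccc12` — in a functional assay on A549 cells (Homo sapiens) for inhibition, read by sulforhodamine B assay, with a stated time of 48 h (a higher number here means a weaker inhibitor of growth, a lower number a stronger inhibitor of growth), compound 1 gives 5000 nM
- compound 2 `COC(=O)[C@@]1(C)CCC=C2[C@@H]1CC[C@@H](C)[C@]2(C)Cc1c[nH]c2c(Br)cccc12` — in this assay compound 2 gives 22000 nM

Within the data shown here, compound 2 holds the highest of the two numbers so far; its only neighbour is compound 1, and the step in this assay is a 4.4-fold higher number from compound 1 to compound 2 (0.64 log units; beyond the scatter), which arises from bromo in place of hydrogen on an aromatic carbon. The pair lies beyond the scatter, so the bromo substituent is read as a real loss of growth inhibition against compound 1 on these two points alone.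

Compound 3 `COC(=O)[C@@]1(C)CCC=C2[C@@H]1CC[C@@H](C)[C@]2(C)Cc1c[nH]c2c(Cl)cccc12` is the next member. Its change from compound 2 is chloro in place of bromo on an aromatic carbon. Among the measured compounds shown here, no measured step speaks to chloro against bromo; the single step on record, from compound 1 to compound 2, shows only that a halogen at this carbon raised the number. Chloro is therefore expected to sit near bromo, with at most a modest step downward in this assay, quite possibly within the scatter. Compound 3 is expected to give 15000 nM, between 6000 nM and 40000 nM, meaning a step of a 1.5-fold lower number from compound 2 to compound 3 (0.17 log units; within the scatter).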

Compound 3, concentration for 50% growth inhibition: 22000 nM
Beside the measured number, compound 3's estimate is 1.5-fold (0.17 log units) below it; low and high end bracket the measured number.
By their numbers in this assay, from the lowest: compound 1; then compounds 2 and 3 (each within the scatter of the next).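

In this assay, among these compounds, exchanging one halogen for the other at this aromatic carbon gives no change at the digits printed from compound 2 to compound 3 (within the scatter), so chloro and bromo cannot be told apart here, something the single step from hydrogen to bromo could not show. The second halogen repeats the loss of growth inhibition, with a 4.4-fold higher number from compound 1 to compound 3 (0.64 log units; beyond the scatter) matching a 4.4-fold higher number from compound 1 to compound 2 (0.64 log units; beyond the scatter), so across these three compounds the higher number goes with either halogen at this carbon and is not particular to bromo. Nothing on hand explains why the two halogens read alike or why either differs from hydrogen.

Still open, on these data alone, is whether the higher number is confined to halogens: fluoro, methyl, methoxy or an amine at the same carbon would test this, as would a halogen on another carbon of the six-membered aromatic ring. Also open, as far as these compounds go, is how much the methyl ester on the shared core contributes to growth inhibition, which a carboxylic acid or an amide in its place would address.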